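A few compounds are considered here, and "the series" means these few. Any claim that something is new, unique, unknown or untested is made for them only; others in the source may bear on it.

Measured so far:
compound 3 `O=C1Nc2ccccc2/C1=N/NC(=S)Nc1ccccc1`: > 25000 nM
compound 1 `Cc1ccc2c(c1)/C(=N/NC(=S)Nc1ccccc1)C(=O)N2`: > 25000 nM
compound 2 `O=C1Nc2ccccc2/C1=N/NC(=S)N1CCCCC1`: > 25000 nM

In an ADME assay on RD cells (Homo sapiens) for cytotoxicity (a higher number here means that more compound is tolerated, a lower number that less compound is tolerated), compound 3 gives > 25000 nM, which is a limit of the assay and not a number. Compound 1 in this assay likewise gives only a limit, > 25000 nM. Compound 2 also sits at a limit, > 25000 nM. Compound 3 therefore stands at the limit of > 25000 nM in this assay, at which 3 of the 3 values shown sit, together with both neighbours, and the two measured steps, a step that the two limits leave unreadable from compound 1 to compound 3 and a step that the two limits leave unreadable from compound 2 to compound 3, cannot be sized.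

Compound 4 `CCN(CC)C(=S)N/N=C1\C(=O)Nc2ccccc21` is the next change on the same thiocarbonyl carbon: diethylamino in place of anilino on a thiocarbonyl carbon. For the measured compounds named here, the closest precedent, the step from piperidin-1-yl to anilino, reads as nothing beyond a limit, so no step beyond the scatter is expected; the expected step is a number no higher from compound 3 to compound 4 (the limit leaves the size open). Compound 4 is estimated at 25000 nM, in the range 12000 nM to 50000 nM, most likely again reported only as a limit.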

Compound 4, half-maximal cytotoxic concentration: > 25000 nM
Compound 4 was reported as a limit (the forecaster's own chance of this, stated with the estimate: 80%); the middle value lies on the limit itself.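

In this assay compound 4 is again only a limit, so its steps from compound 2 and compound 3 cannot be read: the limit of > 25000 nM in this assay, at which 4 of the 4 values shown sit. The compounds shown leave open whether any change on the thiocarbonyl carbon lowers the tolerated concentration.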